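The source may report more compounds than this note shows. Statements on the series, on what has been measured and on what is new or still open speak of the compounds shown alone.

Within the data shown here, in an in vitro ADME assay on microsomes from liver (Mus musculus, strain CD1) for metabolic stability, with a stated time of 30 min, tested at 0.2 uM (a lower number here means slower removal, a higher number faster removal of the compound), compound 1 `COc1ccc(C(=O)Nc2ccccc2NC(=O)c2ccc(N3CCCN(C)CC3)cc2)cc1` gives 2050 mL/min/kg and has only one measured relative for comparison. Compound 2 `COc1ccc(C(=O)Nc2cccc(OC)c2NC(=O)c2ccc(N3CCCN(C)CC3)cc2)cc1` gives 2210 mL/min/kg and stands within the usual scatter of compound 1, so compound 1 holds no distinct place in this very small set. Compound 3 `COc1ccc(C(=O)Nc2ccc(O)cc2NC(=O)c2ccc(N3CCCN(C)CC3)cc2)cc1` has not yet been measured. Its change from compound 1 (hydroxy in place of hydrogen on an aromatic carbon) is hydroxy in place of hydrogen on an aromatic carbon and sits para to a ((4-methoxyphenyl)carbonyl)amino group. Among the measured compounds shown here, the one measured step that bears on this, methoxy in place of hydrogen on an aromatic carbon, is a 1.1-fold higher number from compound 1 to compound 2 (0.03 log units; within the scatter) and involves a different group, so it is only a loose guide. No step beyond the scatter is therefore expected in this assay in either direction. The estimated step is a 1.0-fold lower number from compound 1 to compound 3 (0.01 log units; within the scatter) and nothing larger is expected. Compound 3 is expected to give about 2000 mL/min/kg with an estimated range from 1100 mL/min/kg to 3600 mL/min/kg in this measurement.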

Compound 3, clearance: 1710 mL/min/kg
Compound 3: middle estimate off by 1.2-fold (0.07 log units), on the high side; measured number inside the range.
By their numbers in this assay, from the lowest: compounds 3, 1 and 2 (each within the scatter of the next).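

In this assay, putting a hydroxy on this aromatic carbon, para to a ((4-methoxyphenyl)carbonyl)amino group, gives a 1.2-fold lower number from compound 1 to compound 3 (0.08 log units; within the scatter). Compound 3 is the only compound shown with a group at this position and the only one where the added group is a hydroxy, so it shows that this single change, which adds a hydrogen-bond donor to the core of compound 1, leaves the number within the usual scatter of repeated measurements. No measurement is available that could explain this result.

As far as these compounds go, it remains open whether a different group at this position, such as an amine, a carboxylic acid or a longer alkoxy chain, would give a step beyond the scatter. From the compounds shown here alone, it also remains open whether a hydroxy on another carbon of this ring would give a similar number.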